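Replacing the sulfanyl group of compound 3

The source may hold more compounds than are shown below. What is called first, only, known or untested is meant among the compounds shown, and "the series" means these compounds.

Measured so far in a physicochemical assay for solubility, read by HPLC, with a stated time of 24 h; a lower number here means a less soluble compound, a higher number a more soluble compound:
- Compound 1 `CCN1CCN(C[C@H]2CN(c3ccc(-n4cc(-c5ccccn5)cn4)c(F)c3)C(=O)O2)CC1` at 706000 nM
- Compound 2 `COC[C@H]1CN(c2ccc(-n3cc(-c4ccccn4)cn3)c(F)c2)C(=O)O1` at 36200 nM
- Compound 3 `O=C1O[C@@H](CSc2cccs2)CN1c1ccc(-n2cc(-c3ccccn3)cn2)c(F)c1` at 8500 nM

Compound 3 holds the lowest of the three numbers, and its gaps to both others lie beyond the scatter. Compound 4 `CS(=O)(=O)NC[C@H]1CN(c2ccc(-n3cc(-c4ccccn4)cn3)c(F)c2)C(=O)O1` differs from it in one place (methanesulfonamido in place of (thiophen-2-yl)sulfanyl on a saturated chain carbon bound to a saturated ring carbon). Three measured steps at this place bear on the change, two large (a 20-fold lower number from compound 1 to compound 2 (1.29 log units; beyond the scatter)) and (an 83-fold lower number from compound 1 to compound 3 (1.92 log units; beyond the scatter)) and one modest (a 4.3-fold lower number from compound 2 to compound 3 (0.63 log units; beyond the scatter)). None of them involves methanesulfonamido, so the size remains uncertain. Compound 3 already sits at the bottom, so a modest to large rise is expected in this assay (a 4.7-fold higher number from compound 3 to compound 4 (0.67 log units; beyond the scatter)). For compound 4 the estimated value is 40000 nM, with an expected range from 12000 nM to 150000 nM around it.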

Compound 4, solubility: 2300 nM
Compound 4: middle estimate off by 17-fold (1.24 log units), on the high side, and the stated range ends above it.
By their numbers in this assay, from the lowest: compound 4; then compound 3; then compound 2; then compound 1.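

In this assay, the place on a saturated chain carbon bound to a saturated ring carbon goes lower still than with (thiophen-2-yl)sulfanyl (a 3.7-fold lower number from compound 3 to compound 4 (0.57 log units; beyond the scatter)), so compound 3 did not mark the bottom of this series. Methanesulfonamido removes the aromatic ring and brings a hydrogen-bond donor, yet it also falls well short of methoxy (a 16-fold lower number from compound 2 to compound 4 (1.20 log units; beyond the scatter)) and 4-ethylpiperazin-1-yl (a 310-fold lower number from compound 1 to compound 4 (2.49 log units; beyond the scatter)). No measurement shown explains these falls. On these data alone, whether a carboxylic acid or a simple primary amine at this place would approach compound 1 stays open.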